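This account rests on a few compounds, and the source may have more. Where it says the series, first, only, none or still open, it means among the compounds named here.

Working notes on the series.

Compound 1 `CCO[C@@H](C1=CC2C(C)=NN(c3ccccc3)C2N=C1)[C@H](OC)[C@@H](O)COC` and compound 2 `CCO[C@@H](C1=CC2C(C)=NN(c3ccccc3)C2N=C1)[C@H](O)[C@@H](O)CO` share the same core and differ only in the side chain. In a functional assay on THP-1 cells (Homo sapiens) for cytotoxicity, tested at 10 uM (a higher number here means more inhibition at the concentration tested (going by the name of the read-out), a lower number less inhibition), compound 1 gives 4%, and in this assay compound 2 gives 9%. Going by the values given here, the only measured step, a number 5 percentage points higher from compound 1 to compound 2 (within the scatter), arose from 1,2,3-trihydroxypropyl in place of 2-hydroxy-1,3-dimethoxypropyl on a saturated chain carbon bound to a double-bonded ring carbon and an oxygen on a saturated carbon. Compound 2 thus holds the higher of the two numbers, with compound 1 the nearest, but the two values sit within the scatter of each other, so no order between them can be read.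

Compound 3 `CCO[C@@H](C1=CC2C(C)=NN(c3ccccc3)C2N=C1)[C@H](O)[C@@H](O)COC` is to be measured in this assay. It differs from compound 2 by methyl in place of hydrogen on an oxygen on a saturated carbon. This change runs partway back toward compound 1, which is the step that bears on it: compound 1 to compound 2 gave only a small rise, so the reverse direction, taken halfway, is expected to give no step beyond the scatter. The step from compound 2 to compound 3 in this assay is expected to be a number 2 percentage points lower from compound 2 to compound 3 (within the scatter). For compound 3 the estimate in this assay is 7%, within a range from 0% to 15%.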

Compound 3, a percentage reported as inhibition, at one concentration (the size of the read-out at that concentration, not a potency): 8%
Compound 3: middle estimate off by 1 percentage points, on the low side; measured number inside the range.
By their numbers in this assay, from the lowest: compounds 1, 3 and 2 (each within the scatter of the next).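

In this assay, methyl in place of hydrogen on an oxygen on a saturated carbon, here hydroxymethyl to methoxymethyl, gives a number 1 percentage points lower from compound 2 to compound 3 (within the scatter) and so, taken alone, leaves the read-out within the scatter. The second oxygen that differs between compound 1 and compound 2 can now be looked at separately: hydrogen in place of methyl there gives a number 4 percentage points higher from compound 1 to compound 3 (within the scatter) and is also within the scatter, so the two-place change from the opening pair resolves into two single changes, neither of which can be read as a rise or a fall. No accompanying measurement bears on these numbers.

As far as these compounds go, whether a group larger than methyl on these oxygens, such as ethyl or benzyl, or an amine or a carboxylic acid in place of a hydroxy, would carry the read-out beyond the scatter stays open. The ethoxy group and the phenyl group are the same in all three compounds, so what either contributes to the read-out cannot be told from this set.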